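Swapping vinyl for a carboxylated group on compound 1

The source may hold more compounds than are shown below. What is called first, only, known or untested is meant among the compounds shown, and "the series" means these compounds.

Measured in a functional assay on the whole organism for inhibition, with Cavia porcellus as the target; a lower number here means that less compound is needed, a higher number that more compound is needed for the effect:
- compound 1 `C=CC(=O)N1CCSC1COc1ccccc1OC`: 74 mg/kg
- compound 2 `CCOC(=O)CC(=O)N1CC[S+]([O-])C1COc1ccccc1OC`: 27 mg/kg
- compound 3 `CCOC(=O)CC(=O)N1CCS(=O)(=O)C1COc1ccccc1OC`: 28 mg/kg

Compound 1, at 74 mg/kg, has the highest number of the three, so it needs the most compound for the effect. Its gaps to compound 2 and to compound 3 both lie beyond the usual scatter, and those two compounds have nearly the same value.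

Compound 4 `COc1ccccc1OCC1SCCN1C(=O)C(C)(C)C(=O)O` has not yet been measured. It keeps the core of compound 1 and carries 1-carboxy-1-methylethyl in place of vinyl on a carbonyl carbon.

Among the compounds with values here, no measured pair isolates this kind of change, since compound 2 and compound 3 each differ from compound 1 in more than one place. They are only a loose guide, but compound 2 at 27 mg/kg and compound 3 at 28 mg/kg both point towards a lower number once vinyl is gone. A modest drop is therefore expected, near the edge of the scatter, and the estimated change is a 1.9-fold lower number from compound 1 to compound 4 (0.27 log units; within the scatter).

For compound 4 the estimated value is 40 mg/kg, with an expected range from 15 mg/kg to 100 mg/kg.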

Compound 4, dose for half-maximal effect: 34 mg/kg
Beside the measured number, compound 4's estimate is 1.2-fold (0.07 log units) above it; measured number inside the range.
By their numbers in this assay, from the lowest: compounds 2, 3 and 4 (each within the scatter of the next); then compound 1.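

With the core of compound 1 unchanged, putting 1-carboxy-1-methylethyl in place of vinyl on a carbonyl carbon gives a 2.2-fold lower number from compound 1 to compound 4 (0.34 log units; beyond the scatter) in this assay. Within the data shown here, this is the first single-place change that can be read at this position, and it shows that vinyl is not needed for the effect: the larger group, which carries a hydrogen-bond donor, is accepted here without any need for more compound. The step is modest, and no measurement shown explains it or says which part of the entering group accounts for it.

Going by these compounds, it remains open whether the carboxylic acid itself matters, or whether a simple tert-butyl group on the same carbonyl carbon would do as well. An amine or a longer chain ending in the acid is also untested among the compounds shown.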